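From compound 3 to compound 4: replacing a whole group

A few compounds are considered here, and "the series" means these few. Any claim that something is new, unique, unknown or untested is made for them only; others in the source may bear on it.

Compound 1 `COc1ccc(C2=C(c3ccc(SC)cc3)CC3CCCN3C2=O)cc1O`: 6000 nM
Compound 2 `COc1ccc(C2=C(c3ccc(SC)cc3)CC3CCCN3C2=O)cc1Br`: 900 nM
Compound 3 `COc1ccc(C2=C(c3ccc(SC)cc3)CC3CCCN3C2=O)cc1C`: 900 nM

In a functional assay on DU-145 cells (Homo sapiens) for cytotoxicity (a higher number here means a weaker inhibitor of growth, a lower number a stronger inhibitor of growth), compound 3 stands level with compound 2, and together they give the lowest of the three numbers. Compound 4 `CSc1ccc(C2=C(c3ccc(F)c(F)c3)C(=O)N3CCCC3C2)cc1` has not yet been measured. It differs from compound 3 as follows: 3,4-difluorophenyl in place of 4-methoxy-3-methylphenyl on a double-bonded ring carbon. In words, 3,4-difluorophenyl takes the place of 4-methoxy-3-methylphenyl on a double-bonded ring carbon.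

Among the measured compounds shown here, three measured steps touch this group, each changing only one substituent: a 6.7-fold lower number from compound 1 to compound 2 (0.82 log units; beyond the scatter), a 6.7-fold lower number from compound 1 to compound 3 (0.82 log units; beyond the scatter) and no change at the digits printed from compound 2 to compound 3 (within the scatter). None removes the methoxy group or brings in fluorine, so they offer only a rough guide to size, and none shows the direction. The swap in compound 4 replaces more of the group than any of them, so a step somewhat smaller than a 6.7-fold lower number from compound 1 to compound 3 (0.82 log units; beyond the scatter) is expected, tentatively towards weaker inhibition. The estimated change is a 3.3-fold higher number from compound 3 to compound 4 (0.52 log units; beyond the scatter). For compound 4 the expected value is 3000 nM. The estimated range runs from 800 nM to 12000 nM.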

Compound 4, concentration for 50% growth inhibition: 500 nM
Compound 4: middle estimate off by 6.0-fold (0.78 log units), on the high side; the whole stated range lies above it.
By their numbers in this assay, from the lowest: compounds 4, 2 and 3 (each within the scatter of the next); then compound 1.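

In this assay, 3,4-difluorophenyl sits level with the two groups that gave the lowest earlier numbers (a 1.8-fold lower number from compound 3 to compound 4 (0.26 log units; within the scatter); a 1.8-fold lower number from compound 2 to compound 4 (0.26 log units; within the scatter)), so among these compounds the methoxy group shared by compounds 1, 2 and 3 is not required for growth inhibition at this level. The same replacement on the hydroxy-bearing compound gives a much larger step (a 12-fold lower number from compound 1 to compound 4 (1.08 log units; beyond the scatter)), which leaves compound 1 alone as the compound apart from the other three. Nothing measured here explains why this position accepts such different groups.

As far as these compounds go, whether one fluorine alone, or a phenyl ring with an amine or a carboxylic acid in its place, would perform the same remains open. From the compounds shown here alone, the effect of changing the 4-(methylsulfanyl)phenyl group also remains open, as it is the same in all four compounds.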